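Clearance of Compound 2 and a Pyrimidinyl Replacement

The source may report more compounds than this note shows. Statements on the series, on what has been measured and on what is new or still open speak of the compounds shown alone.

Compound 1 (`CC(=O)c1nc([C@@H](O)[C@H](O)[C@H](O)CO)cn1C`) gives 5.7 mL/min/kg
Compound 2 (`CC(O)c1nc([C@@H](O)[C@H](O)[C@H](O)CO)c[nH]1`) gives 16.4 mL/min/kg

In an in vivo ADME assay on the whole organism (strain 129/SvEvBrd x C57BL/6) for pharmacokinetics, with Mus musculus as the target, at a dose of 1 mg/kg by the intravenous route (on this read-out higher numbers stand for fast clearance and lower numbers for slow clearance), compound 2 stands highest of the two, and its gap to compound 1 lies beyond the usual scatter. Compound 3 (`OC[C@@H](O)[C@@H](O)[C@H](O)c1c[nH]c(-c2ncccn2)n1`) carries pyrimidin-2-yl in place of 1-hydroxyethyl on an aromatic carbon. Among the compounds with values here, no measured pair shows what such a replacement does, so this expectation is loose. No step beyond the scatter is expected in this assay (a 1.2-fold higher number from compound 2 to compound 3 (0.09 log units; within the scatter)). The clearance of compound 3 is estimated at 20 mL/min/kg (range 7 mL/min/kg to 50 mL/min/kg).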

Compound 3, clearance: 15.2 mL/min/kg
The estimate for compound 3 lay 1.3-fold (0.12 log units) above the measured number; measured number inside the range.
By their numbers in this assay, from the lowest: compound 1; then compounds 3 and 2 (each within the scatter of the next).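

In this assay, putting pyrimidin-2-yl in place of 1-hydroxyethyl gives a 1.1-fold lower number from compound 2 to compound 3 (0.03 log units; within the scatter), so at this position a six-membered aromatic ring and a small open group are not told apart by clearance. Within the data shown here, this is the first direct comparison at this position, and it rests on a single pair. Nothing measured here offers a reason for this result.

Compound 1 differs from compound 3 in more than one place, so its value cannot be tied to any one group. On these data alone, how an amine or a carboxylic acid at this position would affect clearance remains open.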